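The compounds below may be only part of what the source reports. "The series", "measured", "known", "first", "only" and "open" are said of these compounds alone.

Compound 1 `C=C1C(=O)OC[C@H]1CCOC(=O)Nc1ccccc1` gives 390 nM in a functional assay on RAW264.7 cells (Mus musculus) for inhibition, with a stated time of 30 min; on this read-out lower numbers stand for stronger inhibition and higher numbers for weaker inhibition. Compound 2 `C=C1C(=O)OC[C@H]1CCOC(=O)Nc1ccc(OC)cc1` gives 710 nM in this assay. Compound 3 `C=C1C(=O)OC[C@H]1CCOC(=O)Nc1ccc(CCCC)cc1` gives 620 nM in this assay.

All three compounds share the same core and differ only in the group on one aromatic carbon. Compound 3 gives a number close to those of compound 1 and compound 2, and none of the three can be set apart from the others on these data: the step of a 1.8-fold higher number from compound 1 to compound 2 (0.26 log units; within the scatter), the step of a 1.6-fold higher number from compound 1 to compound 3 (0.20 log units; within the scatter) and the step of a 1.1-fold lower number from compound 2 to compound 3 (0.06 log units; within the scatter) all fall within the usual scatter of repeated measurements.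

Compound 4 `C=C1C(=O)OC[C@H]1CCOC(=O)Nc1ccc(C(C)C)cc1` differs from compound 3 in one place: isopropyl in place of butyl on an aromatic carbon. The closest guide is the step from compound 1 to compound 3, where a butyl group entered in place of hydrogen, and the step from compound 2 to compound 3, where butyl replaced methoxy; both were within the scatter. Swapping butyl for isopropyl is a smaller change than either, so no step beyond the scatter is expected in this assay. Compound 4 is therefore estimated at 600 nM, with a range from 300 nM to 1200 nM, which corresponds to an expected step of a 1.0-fold lower number from compound 3 to compound 4 (0.01 log units; within the scatter).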

Compound 4, half-maximal inhibitory concentration: 340 nM
Beside the measured number, compound 4's estimate is 1.8-fold (0.25 log units) above it; the measured number falls inside the stated range.
By their numbers in this assay, from the lowest: compounds 4, 1, 3 and 2 (each within the scatter of the next, the first and the last beyond it).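

Isopropyl gives the first pair at this position that can be told apart in this assay: a 2.1-fold lower number from compound 2 to compound 4 (0.32 log units; beyond the scatter) is a modest step, and it is the only one among these compounds that lies beyond the scatter. Isopropyl cannot be separated from butyl or hydrogen, as a 1.8-fold lower number from compound 3 to compound 4 (0.26 log units; within the scatter) and a 1.1-fold lower number from compound 1 to compound 4 (0.06 log units; within the scatter) both lie within the scatter, so four quite different groups at this carbon keep the numbers in a narrow band. Nothing shown explains why this one pair separates.

An amine or a carboxylic acid at this carbon could show whether the narrow band holds for groups of other kinds. Going by these compounds, a chain longer than butyl also remains open, as does any change to the shared core.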